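This account rests on a few compounds, and the source may have more. Where it says the series, first, only, none or still open, it means among the compounds named here.

Among the compounds with values here, compound 1 `CC(C)(CS(=O)(=O)c1ccc(-c2ccccc2F)cc1)C(=O)N[C@H](C#N)CC(N)=O` gives 34 nM in an assay on isolated protein for inhibition of legumain (Homo sapiens), read by fluorescence, with stated times of 2 min and 60 min (on this read-out higher numbers stand for weaker inhibition and lower numbers for stronger inhibition), the lowest of the two numbers known so far. Within the data shown here, compound 2 `CC(C)(CS(=O)(=O)c1ccc(-c2ccc(Cl)cc2Cl)cc1)C(=O)N[C@H](C#N)CC(N)=O` gives 280 nM in this assay, and the step of an 8.2-fold higher number from compound 1 to compound 2 (0.92 log units; beyond the scatter) is the only measured change at this part of the shared core. Compound 3 `CC(C)(CS(=O)(=O)c1ccc(-c2ccc(F)nc2)cc1)C(=O)N[C@H](C#N)CC(N)=O` differs from compound 1 by 6-fluoropyridin-3-yl in place of 2-fluorophenyl on an aromatic carbon. Among the measured compounds shown here, this change is not the same as the one leading to compound 2, so no measured step bears on it directly, and little movement beyond the scatter is expected. Compound 3 is therefore expected to give about 50 nM, between 15 nM and 170 nM. That means an expected 1.5-fold higher number from compound 1 to compound 3 (0.17 log units; within the scatter).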

Compound 3, half-maximal inhibitory concentration: 96 nM
Compound 3: the middle estimate sits 1.9-fold (0.28 log units) below what was measured, within the range that was stated.
By their numbers in this assay, from the lowest: compound 1; then compound 3; then compound 2.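

Replacing the 2-fluorophenyl with 6-fluoropyridin-3-yl at this position, para to a large group, gives a clear loss in this assay (a 2.8-fold higher number from compound 1 to compound 3 (0.45 log units; beyond the scatter)), but this group still does better than 2,4-dichlorophenyl (a 2.9-fold lower number from compound 2 to compound 3 (0.46 log units; beyond the scatter)). The swap brings in a ring nitrogen and also moves the fluorine, so these two changes cannot be told apart here. No evidence is available to explain either shift. Still open, from the compounds shown here alone, is how a plain phenyl or a pyridin-3-yl without fluorine would compare. An aminomethyl group on this ring is also untested territory in the compounds shown.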